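Swapping cyclohexyl for 4-methylphenyl on the amide-type nitrogen

The source may report more compounds than this note shows. Statements on the series, on what has been measured and on what is new or still open speak of the compounds shown alone.

In a functional assay on A-375 cells (Homo sapiens) for antiproliferative activity, read by MTT assay, with a stated time of 72 h (a higher number here means a weaker inhibitor, a lower number a stronger inhibitor), compound 3 (`O=C1COc2ccc(-c3cccc(NS(=O)(=O)c4ccc(F)cc4)c3)cc2N1C1CCCCC1`) gives 23800 nM and compound 1 (`O=C1COc2ccc(-c3cccc(NS(=O)(=O)c4ccc(F)cc4)c3)cc2N1`) gives 20100 nM so the two sit within the scatter of each other. Compound 2 (`O=C1COc2ccc(-c3cccc(NS(=O)(=O)c4ccc(F)cc4)c3)cc2N1C1CC1`) reads > 40000 nM and this is a limit of the assay, not a number.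

Compound 4 (`Cc1ccc(N2C(=O)COc3ccc(-c4cccc(NS(=O)(=O)c5ccc(F)cc5)c4)cc32)cc1`) carries 4-methylphenyl in place of cyclohexyl on an amide-type nitrogen in a ring and has no value yet. The nearest measured changes are at that same nitrogen: a 1.2-fold higher number from compound 1 to compound 3 (0.07 log units; within the scatter) for cyclohexyl in place of hydrogen and an at least 1.9-fold higher number from compound 1 to compound 2 (0.29 log units; that floor lies within the scatter) for cyclopropyl in place of hydrogen and an at least 1.6-fold lower number from compound 2 to compound 3 (0.22 log units; that floor lies within the scatter) for cyclohexyl in place of cyclopropyl. None of these exceeds the scatter, though none involves an aromatic group, so the read-across is loose.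

The expected step is a 1.1-fold lower number from compound 3 to compound 4 (0.03 log units; within the scatter) and thus none beyond the scatter in this assay is anticipated. For compound 4 the estimated value is 22000 nM with an expected range from 9000 nM to 45000 nM on present evidence.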

Compound 4, half-maximal inhibitory concentration: 36200 nM
Compound 4: the middle estimate sits 1.6-fold (0.22 log units) below what was measured, and the stated range covers the measured number.
By their numbers in this assay, from the lowest: compounds 1, 3 and 4 (each within the scatter of the next). At a limit, above all of these: compound 2.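

In this assay, compound 4 is the only compound shown with an aromatic ring on the amide-type nitrogen, and the change from cyclohexyl to 4-methylphenyl stays small (a 1.5-fold higher number from compound 3 to compound 4 (0.18 log units; within the scatter)). The comparison with hydrogen at the same nitrogen also stays small (a 1.8-fold higher number from compound 1 to compound 4 (0.26 log units; within the scatter)), so a six-membered aromatic ring of carbon only is not separated here from either the non-aromatic ring or hydrogen. Compound 2 reads as a limit of the assay, not a number, so the remaining step gives only a floor (an at least 1.1-fold lower number from compound 2 to compound 4 (0.04 log units; that floor lies within the scatter)) and cannot order the two: (the limit of > 40000 nM in this assay, at which 1 of the 4 values shown sits).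

From the compounds shown here alone, whether an amine, a carboxylic acid or a longer chain on this nitrogen would move the number beyond the scatter remains open. Also open, going by these compounds, is whether any substituent here separates from the hydrogen of compound 1.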